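Notes on a bis(trifluoromethyl)benzenesulfonamide series

The compounds below may be only part of what the source reports. "The series", "measured", "known", "first", "only" and "open" are said of these compounds alone.

Measured compounds:
Compound 1, `CN(CCCNS(=O)(=O)c1cc(C(F)(F)F)cc(C(F)(F)F)c1)Cc1ccccc1`. In a functional assay on PANC-1 cells (Homo sapiens) for inhibition, read by MTT assay, with a stated time of 72 h (a lower number here means a stronger inhibitor of growth, a higher number a weaker inhibitor of growth), compound 1 gives only a limit, > 50000 nM.
Compound 2, `O=S(=O)(NCCCNCc1ccccc1)c1cc(C(F)(F)F)cc(C(F)(F)F)c1`. In this assay compound 2 gives 16000 nM.

Compound 2 holds the only number shown in this assay; the other value is a limit, (the limit of > 50000 nM in this assay, at which 1 of the 2 values shown sits). Within the data shown here, the one measured step, an at least 3.1-fold lower number from compound 1 to compound 2 (0.49 log units; beyond the scatter), concerns the amine nitrogen and not the aromatic ring.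

Compound 3, `COc1ccc(CNCCCNS(=O)(=O)c2cc(C(F)(F)F)cc(C(F)(F)F)c2)cc1`, differs from compound 2 by methoxy in place of hydrogen on an aromatic carbon. Among the measured compounds shown here, no measured step touches this ring position, so there is no comparison from which to predict the direction of the change. The expectation for compound 3 in this assay is therefore a step of no change at the digits printed from compound 2 to compound 3 (within the scatter), not beyond the scatter. The estimate for compound 3 is 16000 nM, with a range from 5000 nM to 50000 nM, and some chance that only a limit is returned.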

Compound 3, concentration for 50% growth inhibition: 11000 nM
Beside the measured number, compound 3's estimate is 1.5-fold (0.16 log units) above it; measured number inside the range.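

Methoxy in place of hydrogen on this aromatic carbon gives a 1.5-fold lower number from compound 2 to compound 3 (0.16 log units; within the scatter) in this assay, the first reading at this ring position, and the added group brings no shift beyond the scatter. Exchanging benzyl(methyl)amino for (4-methoxybenzyl)amino gives an at least 4.5-fold lower number from compound 1 to compound 3 (0.65 log units; beyond the scatter), so compound 3 stands with compound 2 on the same side of compound 1. Compound 1 gives only a limit, so that step has no upper end: the limit of > 50000 nM in this assay, at which 1 of the 3 values shown sits.

Going by these compounds, whether other groups at this ring position, such as chlorine, hydroxyl or a nitrile, would also stay within the scatter of compound 2 remains open. So does the effect of a longer chain on the sulfonamide nitrogen, or of an amide in place of the secondary amine.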